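The compounds below may be only part of what the source reports. "The series", "measured", "known", "first", "only" and "open" are said of these compounds alone.

Compound 1 `COc1ccccc1OC(=O)N(Nc1ccccc1)S(=O)(=O)c1ccc(C)cc1`: 34.1 nM
Compound 2 `CCc1ccc(OC(=O)N(Nc2ccccc2)S(=O)(=O)c2ccc(OC)cc2)cc1`: 28.5 nM

Both compounds were tested in a functional assay on RAW264.7 cells (Mus musculus), read by immunoassay, with a stated time of 24 h; a higher number here means a weaker inhibitor, a lower number a stronger inhibitor. Compound 2 gives 28.5 nM and compound 1 gives 34.1 nM. These two numbers lie within the usual scatter of repeated measurements, so they cannot be ranked, and compound 2 simply stands level with compound 1 in the low nanomolar range.

Compound 3 `COc1ccc(S(=O)(=O)N(Nc2ccccc2)C(=O)Oc2ccc3c(c2)CCC3)cc1` is the next case. It keeps the rest of compound 2 and makes one structural change, with 2,3-dihydro-1H-inden-5-yl in place of 4-ethylphenyl on an oxygen next to a carbonyl group. A six-membered aromatic ring of carbon only stays in place, and a five-membered non-aromatic ring of carbon only comes in with it.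

Among the measured compounds shown here, no pair of measured compounds differs in just one place, so the data offer no direct guide to this change. Compound 1 at 34.1 nM and compound 2 at 28.5 nM give the only reference, and in this assay no step beyond the scatter is expected, in either direction. The estimated change is a 1.1-fold higher number from compound 2 to compound 3 (0.02 log units; within the scatter). For compound 3 the expected value is 30 nM, with an estimated range of 12 nM to 75 nM.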

Compound 3, half-maximal inhibitory concentration: 4.5 nM
Compound 3: middle estimate off by 6.7-fold (0.82 log units), on the high side; measured number outside the range, below it.
By their numbers in this assay, from the lowest: compound 3; then compounds 2 and 1 (each within the scatter of the next).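

In this assay, placing 2,3-dihydro-1H-inden-5-yl in place of 4-ethylphenyl on an oxygen next to a carbonyl group gives a 6.3-fold lower number from compound 2 to compound 3 (0.80 log units; beyond the scatter), which shows that the number at this position depends on the group attached there. Both groups hold a six-membered aromatic ring of carbon only, neither has a hydrogen-bond donor or acceptor or a net charge, and the entering group brings a five-membered non-aromatic ring of carbon only, so a change made entirely in carbon is enough to move the result beyond the scatter. No measurement at hand explains why this change has this effect.

This single pair leaves open whether the closed five-membered ring is itself what matters, and a six-membered non-aromatic ring in its place, a longer chain such as propyl on the phenyl ring, or an amine on that ring would each test a different part of the question. It also leaves open whether the same change would give a similar step on the core of compound 1.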